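A few compounds are considered here, and "the series" means these few. Any claim that something is new, unique, unknown or untested is made for them only; others in the source may bear on it.

Of the compounds shown here, three sharing one core have been tested in a functional assay on HT-29 cells (Homo sapiens) for cytotoxicity, read by MTT assay, with a stated time of 72 h; a lower number here means a stronger inhibitor, a higher number a weaker inhibitor. Compound 2 `Cc1ccc(Cn2ccnc2/C=N/Nc2nc(NCCN(C)C)c3ccccc3n2)cc1` gives 1410 nM there; compound 1 `CN(C)CCNc1nc(N/N=C/c2nccn2Cc2ccccc2)nc2ccccc12` gives 2620 nM and compound 3 `CN(C)CCNc1nc(N/N=C/c2nccn2Cc2ccc(F)cc2)nc2ccccc12` gives 930 nM, so compound 2 sits between them, though a 1.9-fold lower number from compound 1 to compound 2 (0.27 log units; within the scatter) and a 1.5-fold lower number from compound 2 to compound 3 (0.18 log units; within the scatter) both fall within the scatter, while a 2.8-fold lower number from compound 1 to compound 3 (0.45 log units; beyond the scatter) is modest. Compound 4 `Cc1ccc(Cn2ccnc2/C=N/Nc2nc(NCCCN(C)C)c3ccccc3n2)cc1` differs from compound 2 by (dimethylamino)methyl in place of dimethylamino on a saturated chain carbon, two bonds along the chain from a nitrogen on an aromatic ring. Every measured step instead swaps a group on an aromatic carbon, so none speaks directly to lengthening this chain. With nothing in the data pointing either way, the step from compound 2 to compound 4 is expected to be a 1.0-fold lower number from compound 2 to compound 4 (0.00 log units; within the scatter), and compound 4 is estimated at 1400 nM, between 500 nM and 4000 nM.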

Compound 4, half-maximal inhibitory concentration: 2440 nM
Compound 4: the middle estimate sits 1.7-fold (0.24 log units) below what was measured; the measured number falls inside the stated range.
By their numbers in this assay, from the lowest: compounds 3, 2, 4 and 1 (each within the scatter of the next, the first and the last beyond it).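

Going by these compounds alone, this is the first change to the side chain rather than to a group on an aromatic carbon: going from (2-(dimethylamino)ethyl)amino to (3-(dimethylamino)propyl)amino in this assay gives a step that stays within the scatter (a 1.7-fold higher number from compound 2 to compound 4 (0.24 log units; within the scatter)). At this position, then, the longer chain cannot be told apart from the shorter one. No measurement here offers an explanation for this result. Still open, as far as these compounds go, is how a longer chain, such as 4-(dimethylamino)butyl, would read, and whether a primary amine or a carboxylic acid could replace the dimethylamino end.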